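Removing a side chain from a weak indole-derived inhibitor series

The source may report more compounds than this note shows. Statements on the series, on what has been measured and on what is new or still open speak of the compounds shown alone.

Measured compounds:
- compound 1, `C=CC(C)(C)c1[nH]c2ccccc2c1/C=C1\NC(=O)C(C)(OC)NC1=O`, 99000 nM
- compound 2, `C=CC(C)(C)c1[nH]c2ccc(CC=C(C)C)cc2c1/C=C1\NC(=O)C(C)(OC)NC1=O`, 79000 nM
- compound 3, `C=CC(C)(C)c1[nH]c2ccc(CC=C(C)C)cc2c1/C=C1\NC(=O)[C@H](C)NC1=O`, 98000 nM

In a functional assay (a lower number here means a stronger inhibitor, a higher number a weaker inhibitor), all three compounds give high numbers, so each is a weak inhibitor. Compound 1 and compound 2 share one core, and the step of a 1.3-fold higher number from compound 2 to compound 1 (0.10 log units; within the scatter) shows that the change hydrogen in place of 3-methylbut-2-en-1-yl on an aromatic carbon barely moves the number. Compound 3 carries a different core; the difference between the two cores is not broken down here, yet its value sits within the scatter of both others.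

Compound 4, `C=CC(C)(C)c1[nH]c2ccccc2c1/C=C1\NC(=O)[C@H](C)NC1=O`, has not yet been measured. It arises from compound 3 by the same change, (hydrogen in place of 3-methylbut-2-en-1-yl on an aromatic carbon). Because the step of a 1.3-fold higher number from compound 2 to compound 1 (0.10 log units; within the scatter) lay within the scatter, a similarly small step a 1.2-fold higher number from compound 3 to compound 4 (0.09 log units; within the scatter) is expected in this assay, resting on that single earlier pair. Compound 4 is therefore estimated at 120000 nM, with a likely range from 50000 nM to 280000 nM.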

Compound 4, half-maximal inhibitory concentration: 103000 nM
Compound 4: middle estimate off by 1.2-fold (0.07 log units), on the high side; the range from low to high includes it.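

In this assay, replacing 3-methylbut-2-en-1-yl with hydrogen on the aromatic carbon gives a 1.1-fold higher number from compound 3 to compound 4 (0.02 log units; within the scatter), so this step on the second core also stays small. Set side by side, the two steps agree: the same change on two cores in this assay, a 1.3-fold higher number (0.10 log units; within the scatter) from compound 2 to compound 1 and a 1.1-fold higher number (0.02 log units; within the scatter) from compound 3 to compound 4, 1.2-fold (0.08 log units) apart, within the scatter of two such steps

Among these compounds, this shows that the change carries over between these two cores, but it rests on only two pairs of weak inhibitors. It does not show that the same would hold on any other core, or in a much stronger inhibitor.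

As far as these compounds go, only hydrogen and 3-methylbut-2-en-1-yl appear at this aromatic carbon, so it remains open how an amine, a carboxylic acid or a longer chain there would read in this assay. Whether any group at this place can move the number beyond the scatter also stays unanswered.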